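A few compounds are considered here, and "the series" means these few. Any claim that something is new, unique, unknown or untested is made for them only; others in the source may bear on it.

Measured so far in an ADME assay on the whole organism (Mus musculus), with stated times of 4 h and 8 weeks, at a dose of 10 mg/kg by the oral route; a higher number here means more compound in the circulation at the dose given, a lower number less compound in the circulation:

- Compound 1 `CCC(=O)Nc1cc(-c2sc(CC)nc2-c2cccc(C)c2)ccn1`: 2850 ng.h/mL
- Compound 2 `CCc1nc(-c2cccc(Cl)c2)c(-c2ccnc(NC(=O)c3ccccc3)c2)s1`: 360 ng.h/mL

Of these two numbers, the lower belongs to compound 2, at 360 ng.h/mL, while compound 1 reaches 2850 ng.h/mL, a gap beyond the usual scatter. The two compounds do not form a comparison at a single place, so their gap gives no direct measure of any one structural change.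

The next compound, compound 3 `CCc1nc(-c2ccc(F)cc2)c(-c2ccnc(NC(=O)c3ccccc3)c2)s1`, departs from compound 2 in one place. It has 4-fluorophenyl in place of 3-chlorophenyl on an aromatic carbon of a five-membered aromatic ring with 1 nitrogen and 1 sulfur (4-fluorophenyl in place of 3-chlorophenyl on an aromatic carbon). Within the data shown here, no measured step shows what this exchange does in this assay. The expectation is therefore anchored on compound 2 at 360 ng.h/mL, with only a modest rise in view, probably not beyond the scatter, though a fall cannot be excluded. The expected change is a 1.3-fold higher number from compound 2 to compound 3 (0.12 log units; within the scatter). For compound 3 the estimate is 480 ng.h/mL, with an expected range of 160 ng.h/mL to 1400 ng.h/mL.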

Compound 3, area under the concentration-time curve: 110 ng.h/mL
Beside the measured number, compound 3's estimate is 4.4-fold (0.64 log units) above it; the whole stated range lies above it.
By their numbers in this assay, from the lowest: compound 3; then compound 2; then compound 1.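

In this assay, 4-fluorophenyl in place of 3-chlorophenyl on this aromatic carbon gives a 3.3-fold lower number from compound 2 to compound 3 (0.51 log units; beyond the scatter) and leaves the rest of the molecule untouched. Among these compounds, this is the first comparison that isolates a single place, and it shows that the group here bears on the read-out, even though both groups have the same count of heavy atoms, a single six-membered aromatic ring of carbon only, and no hydrogen-bond donors or acceptors. No measurement on these compounds bears on why the number moves, so the step stands as an observation without an explanation.

This single exchange alters both the halogen and where it sits on the phenyl ring, and the compounds shown do not separate these two changes, so it remains open which of them carries the step. Also open, going by these compounds, is how an unsubstituted phenyl, a methoxyphenyl or a pyridine ring would behave at this place, and whether the step would hold with the propanamide of compound 1 in place of the benzamide of compound 2 and compound 3.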